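Lengthening the Alkyne Chain on the Methyl-Bearing Core

This account rests on a few compounds, and the source may have more. Where it says the series, first, only, none or still open, it means among the compounds named here.

Compound 3 `CCCCCCC#Cc1cc2cn(C)c(=O)nc2o1` has been tested in a functional assay on HEL cells (Homo sapiens) for cytotoxicity; on this read-out lower numbers stand for higher toxicity in this test and higher numbers for lower toxicity in this test. In this assay compound 3 gives > 194000 nM, which is a limit of the assay and not a number. Compound 1 `CCCCCCCCC#Cc1cc2cn(C)c(=O)nc2o1` also reaches only a limit: in this assay compound 1 gives > 175000 nM. Compound 2 `CCCCCCCCCCC#Cc1cc2cn([C@H]3C[C@H](O)[C@@H](CO)O3)c(=O)nc2o1` carries a different group on the shared core in place of the methyl; in this assay compound 2 gives 36000 nM. Compound 4 `CCCCCCCCCCC#Cc1cc2cn(C)c(=O)nc2o1` differs from compound 3 by butyl in place of hydrogen on a saturated chain carbon, six bonds along the chain from a triple-bonded carbon. Going by the values given here, the only measured step on this chain, a step that the two limits leave unreadable from compound 1 to compound 3, has no readable size because the limit of > 175000 nM in this assay, at which 1 of the 3 values shown sits, and the limit of > 194000 nM in this assay, at which 1 of the 3 values shown sits, are both limits, so no direction can be taken from it. No step between compound 2 and compound 4 is shown, and its value alone sets no expectation for the methyl-bearing core. Compound 4 is therefore expected to give an estimated 150000 nM, between 40000 nM and 400000 nM. The expected step is an at least 1.2-fold lower number from compound 3 to compound 4 (0.11 log units; that floor lies within the scatter).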

Compound 4, half-maximal cytotoxic concentration: > 150000 nM
Compound 4 ended at the assay's limit (the forecaster's own chance of this, stated with the estimate: 55%); the middle value sits exactly at the limit.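

Going by these compounds alone, the one step that can be read in this assay is an at least 4.1-fold higher number from compound 2 to compound 4 (0.61 log units; beyond the scatter). Both compounds carry the same long alkyne chain, so this step rests only on methyl in place of 4-hydroxy-5-(hydroxymethyl)oxolan-2-yl on an aromatic nitrogen, and it shows that the group on that nitrogen changes the read-out with this chain. Even with butyl added to the chain of compound 3, no measured number appears for the methyl-bearing core: compound 4 gives > 150000 nM, a limit of the assay and not a number, and the steps from compound 3 and compound 1 to compound 4 cannot be read.

Whether chain length changes the read-out at all remains open, on the methyl-bearing core and with the oxolanyl group, which is shown with one chain only. Also open, going by these compounds, is how a group such as propyl in place of methyl on the aromatic nitrogen would compare.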